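The compounds below may be only part of what the source reports. "The series", "measured", "known", "first", "only" and "open" are said of these compounds alone.

Measured so far in a functional assay on HeLa cells (Homo sapiens) for inhibition, read by MTT assay, with a stated time of 48 h; a higher number here means a weaker inhibitor, a lower number a stronger inhibitor:
- compound 1 `COc1cccc(C(c2c[nH]c3ccc(Br)cc23)c2c[nH]c3ccc(Br)cc23)c1OC`: 64500 nM
- compound 2 `Brc1ccc2[nH]cc(C(c3c[nH]c4ccc(Br)cc34)C3CCCCC3)c2c1`: 3200 nM
- compound 3 `Brc1ccc(C(c2c[nH]c3ccc(Br)cc23)c2c[nH]c3ccc(Br)cc23)cc1`: 1500 nM

Compound 3 holds the lowest number of the three, and both of the others lie beyond the scatter from it. Next is compound 4 `O=[N+]([O-])c1ccc(C(c2c[nH]c3ccc(Br)cc23)c2c[nH]c3ccc(Br)cc23)cc1`, with nitro in place of bromo on an aromatic carbon, para to a large group, so 4-bromophenyl becomes 4-nitrophenyl: nitro in place of bromo on an aromatic carbon.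

Among the measured compounds shown here, no measured step makes this exact change. The nearest evidence comes from replacing the whole group on the saturated chain carbon. The large step of a 43-fold lower number from compound 1 to compound 3 (1.63 log units; beyond the scatter) and the modest step of a 2.1-fold lower number from compound 2 to compound 3 (0.33 log units; beyond the scatter) both end at the 4-bromophenyl of compound 3. They show that numbers in this assay can move widely with this group, but they say little about a single substituent swap. A modest step towards a higher number is therefore expected, though no change beyond the scatter remains possible. The expected step is a 1.7-fold higher number from compound 3 to compound 4 (0.22 log units; within the scatter). For compound 4 the estimated value is 2500 nM, with an expected range from 600 nM to 12000 nM.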

Compound 4, half-maximal inhibitory concentration: 1500 nM
For compound 4 the middle estimate is 1.7-fold (0.22 log units) above the measured one; the range from low to high includes it.
By their numbers in this assay, from the lowest: compounds 3 and 4 (each within the scatter of the next); then compound 2; then compound 1.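

In this assay, among the compounds shown here, the only single-substituent swap on this aromatic ring gives no change at the digits printed from compound 3 to compound 4 (within the scatter), so at this carbon, para to a large group, nitro with its 3 heavy atoms and 2 hydrogen-bond acceptors reads alike with bromo, which has 1 heavy atom and no acceptor. Against the other groups on the saturated chain carbon, 4-nitrophenyl gives a 2.1-fold lower number from compound 2 to compound 4 (0.33 log units; beyond the scatter) and a 43-fold lower number from compound 1 to compound 4 (1.63 log units; beyond the scatter), so the order of these groups holds with either substituent on the phenyl ring. No measurement on hand accounts for the match between nitro and bromo.

Two substituents cannot show whether this carbon tolerates change generally, and an amine or a carboxylic acid at the same place could still shift the number. The need for any substituent here also remains open, as plain phenyl is absent from the compounds shown.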